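The compounds below may be only part of what the source reports. "The series", "measured", "known", "first", "only" and "open" are said of these compounds alone.

Measured compounds:
- compound 1 `O=c1c(C(=S)Nc2ccccc2)coc2cc(Cl)ccc12`: 56%
- compound 2 `O=c1c(C2N=C(c3ccccc3)SS2)coc2cc(Cl)ccc12`: 53%
- compound 3 `O=c1c(C2N=C(c3ccccc3)SS2)coc2ccccc12`: 82%

All three numbers come from a functional assay on IMR-32 cells (Homo sapiens) for inhibition, read by sulforhodamine B assay, with a stated time of 48 h, tested at 100 uM; a lower number here means less inhibition of growth, a higher number more inhibition of growth at the concentration tested. Compound 1 and compound 2 carry different cores; the difference between the two cores is not broken down here, and their two values lie within the scatter of each other, so nothing is read into that gap. Between compound 2 and compound 3 the change is hydrogen in place of chloro on an aromatic carbon, and it gives a number 29 percentage points higher from compound 2 to compound 3 (beyond the scatter).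

Compound 4 `O=c1c(C(=S)Nc2ccccc2)coc2ccccc12` is not yet measured. Against compound 1 it shows (hydrogen in place of chloro on an aromatic carbon), the same change as from compound 2 to compound 3, at a place described in the same words. For the measured compounds named here, the expectation for compound 4 therefore rests on the single measured instance of this change: the step from compound 1 to compound 4 is estimated as a number 24 percentage points higher from compound 1 to compound 4 (beyond the scatter), set beside the earlier one because of a number 29 percentage points higher from compound 2 to compound 3 (beyond the scatter). Going by the values given here, only one such pair exists, so the range is kept wide. Compound 4 is estimated at 80%, between 62% and 95%, in this assay.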

Compound 4, percent growth inhibition at one concentration: 53%
The estimate for compound 4 lay 27 percentage points above the measured number; the measured number lies below the stated range.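

In this assay, hydrogen in place of chloro on an aromatic carbon gives a number 3 percentage points lower from compound 1 to compound 4 (within the scatter), so the step seen on the other core does not repeat here. For the compounds shown here, the same change therefore cannot be carried from one core to the other at a fixed size: the same change on two cores in this assay, a number 29 percentage points higher (beyond the scatter) from compound 2 to compound 3 and a number 3 percentage points lower (within the scatter) from compound 1 to compound 4, 32 percentage points apart, beyond the scatter of two such steps With only one pair on each core, this shows that the outcome of the change differed between these two cores, but it does not show what in the cores accounts for the difference or how the change would behave on a further core.

Other groups in place of the chloro, such as fluoro, methoxy or an amine, remain open, as does whether any of them would give different steps on the two cores. Going by these compounds alone, also open is whether the change on a third core would resemble the step seen with compound 3 or the one seen with compound 4.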